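Oral exposure notes: the step from compound 2 to compound 3

The source may hold more compounds than are shown below. What is called first, only, known or untested is meant among the compounds shown, and "the series" means these compounds.

Two structurally distinct compounds have been measured so far in an ADME assay on the whole organism (Rattus norvegicus, strain Sprague-Dawley) for pharmacokinetics, using cassette dosing, at a dose of 1 mg/kg by the oral route; a lower number here means that a smaller share of the oral dose reaches the circulation, a higher number that a larger share of the oral dose reaches the circulation. Compound 1 (`O=C(c1cc(-c2ccc(=O)[nH]c2)on1)N1CCC(Cc2ccccc2)CC1`) gives 18.4%, and compound 2 (`O=C(Nc1ccc2[nH]c(=O)oc2c1)C(=O)N1CCN(c2ccc(F)cc2)CC1`) gives 39.3%. Compound 2 is the higher of the two, and the gap lies beyond the usual scatter. The two compounds differ in more than one place, so their gap cannot be assigned to any single group.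

Compound 3 (`COc1ccc(N2CCN(C(=O)C(=O)Nc3ccc4[nH]c(=O)oc4c3)CC2)cc1F`) keeps the core of compound 2 and changes one group: 3-fluoro-4-methoxyphenyl in place of 4-fluorophenyl on an amine nitrogen in a ring. For the measured compounds named here, no measured pair shows the size of a change at this place, so the expectation is anchored on compound 2 at 39.3%. Only a small downward step, within the scatter, is expected, and the direction is a weak lean. The expected change is an estimated a number 6.3 percentage points lower from compound 2 to compound 3 (within the scatter). In this assay, compound 3 is expected at 33%, with an estimated range of 16% to 50%.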

Compound 3, oral bioavailability: 0.6%
For compound 3 the middle estimate is 32.4 percentage points above the measured one, and the stated range ends above it.
By their numbers in this assay, from the lowest: compound 3; then compound 1; then compound 2.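

For the compounds shown here, this is the first measured step at this position, on an amine nitrogen in a ring, and it shows that the group held there can matter greatly in this assay: 3-fluoro-4-methoxyphenyl in place of 4-fluorophenyl gives a number 38.7 percentage points lower from compound 2 to compound 3 (beyond the scatter) with the rest of the structure unchanged. The exchange looks modest on paper, since a six-membered aromatic ring of carbon only stays in place, fluorine stays present, no net charge enters, and the entering group differs mainly by a methoxy oxygen that counts as a hydrogen-bond acceptor, yet the step is large. Nothing at hand bears on the reason for so large a step.

The compounds shown leave open which part of the entering group goes with the step, the methoxy group or the altered fluorine placement, and a single pair cannot settle this. A 4-methoxyphenyl group and a 3-fluorophenyl group on the same ring nitrogen, each compared directly with compound 2, would separate the two parts of this change.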